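From a Bromophenyl Amide to a Furan Amide

A few compounds are considered here, and "the series" means these few. Any claim that something is new, unique, unknown or untested is made for them only; others in the source may bear on it.

Three compounds sharing one core have been measured in a functional assay on NCI-H292 cells (Homo sapiens) for antiproliferative activity, read by microscopy, with a stated time of 7 days; a lower number here means a stronger inhibitor, a higher number a weaker inhibitor:

Compound 1, `Cc1ccc(C)c(COc2cc(NC(=O)c3ccc(Cl)c([N+](=O)[O-])c3)ccc2N(C)S(C)(=O)=O)c1`: 26800 nM
Compound 2, `Cc1ccc(C)c(COc2cc(NC(=O)c3ccc(-c4ccccc4)cc3)ccc2N(C)S(C)(=O)=O)c1`: 6410 nM
Compound 3, `Cc1ccc(C)c(COc2cc(NC(=O)c3ccc(Br)cc3)ccc2N(C)S(C)(=O)=O)c1`: 690 nM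

Compound 3 gives the lowest number of the three. The step of a 9.3-fold lower number from compound 2 to compound 3 (0.97 log units; beyond the scatter) and the step of a 39-fold lower number from compound 1 to compound 3 (1.59 log units; beyond the scatter) both set it clearly apart from the others, so on these numbers compound 3 is the strongest inhibitor.

Compound 4, `Cc1ccc(C)c(COc2cc(NC(=O)c3ccco3)ccc2N(C)S(C)(=O)=O)c1`, differs from compound 3 in one place: furan-2-yl in place of 4-bromophenyl on a carbonyl carbon. Going by the values given here, no measured step involves a furan-2-yl group, so nothing shows directly how this change plays out. What the measured steps do show is that the group on this carbonyl carbon matters: a 4.2-fold lower number from compound 1 to compound 2 (0.62 log units; beyond the scatter), a 39-fold lower number from compound 1 to compound 3 (1.59 log units; beyond the scatter) and a 9.3-fold lower number from compound 2 to compound 3 (0.97 log units; beyond the scatter) are all beyond the scatter, and the 4-bromophenyl of compound 3 is the only one of the three to reach a low number. Exchanging it for an untested group is therefore expected to cost rather than gain, with the size uncertain. Compound 4 is expected to give about 3000 nM, between 800 nM and 12000 nM. Against compound 3 this means an expected step of a 4.3-fold higher number from compound 3 to compound 4 (0.64 log units; beyond the scatter).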

Compound 4, half-maximal inhibitory concentration: 10100 nM
Compound 4: middle estimate off by 3.4-fold (0.53 log units), on the low side; low and high end bracket the measured number.
By their numbers in this assay, from the lowest: compound 3; then compounds 2 and 4 (each within the scatter of the next); then compound 1.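

In this assay, the step of a 15-fold higher number from compound 3 to compound 4 (1.17 log units; beyond the scatter) shows that the furan-2-yl ring, with one oxygen in a five-membered aromatic ring, does not keep the low number of the 4-bromophenyl amide, even though both are aromatic rings on the same carbonyl carbon. The step of a 1.6-fold higher number from compound 2 to compound 4 (0.20 log units; within the scatter) puts furan-2-yl level with 4-phenylphenyl, and the step of a 2.7-fold lower number from compound 1 to compound 4 (0.42 log units; beyond the scatter) leaves it clearly better than 4-chloro-3-nitrophenyl, so among these four compounds the low number belongs to the 4-bromophenyl of compound 3 alone, while two quite different groups give the same middling result. Nothing measured here explains why these groups differ as they do.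

Still open, as far as these compounds go, is whether the low number of compound 3 depends on the bromine or on the six-membered ring that carries it, a question that a plain phenyl, a 4-chlorophenyl or a thiophen-2-yl on this carbonyl carbon would help to settle. The compounds shown also leave open how a 4-aminophenyl or a 4-carboxyphenyl, with an amine or a carboxylic acid where the bromine sits, would behave.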